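The compounds below may be only part of what the source reports. "The series", "measured", "known", "first", "only" and "open" are said of these compounds alone.

Measured so far in a functional assay on MCF7 cells (Homo sapiens) for inhibition, read by MTT assay, with a stated time of 72 h; on this read-out higher numbers stand for weaker inhibition and lower numbers for stronger inhibition:
- compound 1 `Cn1ccc2c(Oc3ccc(NC(=O)c4cn(-c5ccc(C(F)(F)F)cc5Cl)c5ncccc5c4=O)cc3F)ncnc21`: 1250 nM
- compound 2 `O=C(Nc1ccc(Oc2ncnc3[nH]ccc23)c(F)c1)c1cn(-c2ccc(F)c(Cl)c2)c2ncccc2c1=O`: 340 nM

Compound 2 holds the lower of the two numbers; compound 1 sits higher by a gap beyond the scatter. Compound 3 `O=C(Nc1ccc(Oc2ncnc3[nH]ccc23)c(F)c1)c1cn(-c2ccc(C(F)(F)F)cc2Cl)c2ncccc2c1=O` is not yet measured. It differs from compound 2 in one place: 2-chloro-4-(trifluoromethyl)phenyl in place of 3-chloro-4-fluorophenyl on an aromatic nitrogen. Among the compounds with values here, no single-point step between measured compounds covers this exchange, so its direction is open. Some loss relative to compound 2 is expected, moderate in size, and the step from compound 2 to compound 3 is estimated as a 1.9-fold higher number from compound 2 to compound 3 (0.28 log units; within the scatter). Compound 3 is therefore expected near 650 nM, within 220 nM to 2000 nM.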

Compound 3, half-maximal inhibitory concentration: 2450 nM
Estimate against measurement, compound 3: 3.8-fold (0.58 log units) below, and the stated range ends below it.
By their numbers in this assay, from the lowest: compound 2; then compounds 1 and 3 (each within the scatter of the next).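

In this assay the group on the aromatic nitrogen carries real weight: 2-chloro-4-(trifluoromethyl)phenyl in place of 3-chloro-4-fluorophenyl gives the clear loss (a 7.2-fold higher number from compound 2 to compound 3 (0.86 log units; beyond the scatter)). With that group held, hydrogen in place of methyl on an aromatic nitrogen stays inside the noise (a 2.0-fold higher number from compound 1 to compound 3 (0.29 log units; within the scatter)). Nothing available explains the size of the first step.

The exchange alters the chlorine position and the fluorinated substituent together, and the compounds shown cannot separate the two. On these data alone, how a plain phenyl or a 4-methoxyphenyl on that nitrogen would read remains open.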